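Two Dimeric Coumarins and an Untested Phenol Analogue

The source may report more compounds than this note shows. Statements on the series, on what has been measured and on what is new or still open speak of the compounds shown alone.

Measured so far:
compound 1 `O=c1oc2ccc(Cl)cc2c(O)c1C(c1ccc(Cl)cc1Cl)c1c(O)c2cc(Cl)ccc2oc1=O` gives 16500 nM
compound 2 `CCOc1cc(C(c2c(O)c3cc(C)ccc3oc2=O)c2c(O)c3cc(C)ccc3oc2=O)ccc1O` gives 221000 nM

Both compounds were tested in an assay on isolated protein for inhibition of Maltase-glucoamylase (Homo sapiens); on this read-out higher numbers stand for weaker inhibition and lower numbers for stronger inhibition. Of the two, compound 1 stands at the lower number, and its gap to compound 2 lies beyond the usual scatter. Among the compounds with values here, compound 2 differs from compound 1 in more than one place, so no single step between them can be drawn; their two values alone show that the chloro-bearing core with a 2,4-dichlorophenyl group gives the stronger inhibition of the pair.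

Compound 3 `COc1ccc(C(c2c(O)c3cc(Cl)ccc3oc2=O)c2c(O)c3cc(Cl)ccc3oc2=O)cc1O` has not yet been measured. It keeps the core of compound 1 and changes only the group on the central carbon: 3-hydroxy-4-methoxyphenyl in place of 2,4-dichlorophenyl on a saturated chain carbon bound to two aromatic carbons. Within the data shown here, no measured pair shows this exact change. Compound 2, which also carries a phenyl ring bearing hydroxy and alkoxy groups, gives the weaker number, but its core differs too, so its value is only a loose hint.

Compound 3 is expected to be a modest step weaker, a 2.4-fold higher number from compound 1 to compound 3 (0.38 log units; beyond the scatter), perhaps not clearly beyond the scatter. The estimated value of compound 3 is 40000 nM, with a range from 10000 nM to 160000 nM.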

Compound 3, half-maximal inhibitory concentration: 113000 nM
Beside the measured number, compound 3's estimate is 2.8-fold (0.45 log units) below it, and the stated range covers the measured number.
By their numbers in this assay, from the lowest: compound 1; then compounds 3 and 2 (each within the scatter of the next).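

In this assay, within the data shown here, replacing 2,4-dichlorophenyl with 3-hydroxy-4-methoxyphenyl on a saturated chain carbon bound to two aromatic carbons gives a 6.8-fold higher number from compound 1 to compound 3 (0.84 log units; beyond the scatter) and so provides the first comparison in this set that differs in only one place. With the core of compound 1 held constant, it shows that the group at this position can alone change inhibition by more than the usual scatter, and that here the dichlorinated ring gives the stronger inhibition. However, the swap removes both chlorine atoms and adds a hydroxy and a methoxy group in a single move, and nothing measured here accounts for the step.

The compounds shown leave open which part of this swap matters most, a question that a phenyl ring with a single chlorine, a lone hydroxy group or a lone methoxy group could help to separate. They also leave open how this position would respond to an unsubstituted phenyl ring, or to a phenyl ring carrying an amine or a carboxylic acid.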